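From compound 2 to compound 3: adding a nitro group

This account rests on a few compounds, and the source may have more. Where it says the series, first, only, none or still open, it means among the compounds named here.

compound 1 `CC(=O)SCCC(CCCCC(=O)O)SC(C)=O` gives "not active" (no number reported)
compound 2 `O=C(CCCCC1CCSS1)Nc1cccc(C(F)(F)F)c1` gives 4.76%

Among the compounds with values here, in a functional assay on HO8910 cells (Homo sapiens) for inhibition, read by MTT assay, with a stated time of 24 h, tested at 1 ug/mL (a higher number here means more inhibition of growth at the concentration tested, a lower number less inhibition of growth), compound 2 holds the only number, and compound 1 has none. Compound 3 `O=C(CCCCC1CCSS1)Nc1ccc([N+](=O)[O-])c(C(F)(F)F)c1` differs from compound 2 in one place: nitro in place of hydrogen on an aromatic carbon, ortho to a trifluoromethyl group and para to a large group (nitro in place of hydrogen on an aromatic carbon). Within the data shown here, no measured pair shows this change, so no step beyond the scatter is expected in this assay. The estimated step stays small (a number 3.2 percentage points higher from compound 2 to compound 3 (within the scatter)). Compound 3 is expected at 8% (estimated range 0% to 25%).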

Compound 3, percent growth inhibition at one concentration: 0.96%
Compound 3: the middle estimate sits 7 percentage points above what was measured; measured number inside the range.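

In this assay, nitro in place of hydrogen on the aromatic carbon ortho to a trifluoromethyl group and para to a large group gives a number 3.8 percentage points lower from compound 2 to compound 3 (within the scatter) and so leaves no change that can be told from the scatter. This position therefore takes the added nitro group without any readable gain or loss in growth inhibition. Nothing measured bears on why this is so. On these data alone, whether an amine or a nitrile on this same aromatic carbon would give a step beyond the scatter remains open.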